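Moving a ring closer in compound 1

The source may hold more compounds than are shown below. What is called first, only, known or untested is meant among the compounds shown, and "the series" means these compounds.

- Compound 1 `CC(C)C(CC1C(=O)NC(=O)N1C)c1ccc(-c2ccc3cccc(F)c3c2)[nH]c1=O`: 0.153 h
- Compound 2 `O=C1NC(=O)/C(=C/C(c2ccc(-c3ccc4cccc(F)c4c3)[nH]c2=O)C2CCCCC2)O1`: 1.09 h
- Compound 3 `CC(C)/C(=C1/OC(=O)NC1=O)c1ccc(-c2ccc3cccc(F)c3c2)[nH]c1=O`: > 3 h (a limit)

In an ADME assay on microsomes from liver (Homo sapiens) for metabolic stability (a lower number here means that the compound disappears faster, a higher number that the compound lasts longer), compound 1 gives 0.153 h, the lower of the two actual numbers, and compound 2 gives 1.09 h, a gap beyond the usual scatter. The entry for compound 3 is a limit of the assay, not a number.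

Compound 4 `CC(C)C(c1ccc(-c2ccc3cccc(F)c3c2)[nH]c1=O)C1C(=O)NC(=O)N1C` carries 3-methyl-2,5-dioxoimidazolidin-4-yl in place of (3-methyl-2,5-dioxoimidazolidin-4-yl)methyl on a saturated chain carbon bound to an aromatic carbon and a saturated chain carbon. Among the compounds with values here, no measured pair shows this kind of change, so no step beyond the scatter is expected in this assay. The estimated 1.3-fold higher number from compound 1 to compound 4 (0.12 log units; within the scatter) reflects this. For compound 4, the expected half-life is 0.2 h, with an estimated range of 0.07 h to 0.6 h.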

Compound 4, half-life: 0.375 h
For compound 4 the middle estimate is 1.9-fold (0.27 log units) below the measured one, within the range that was stated.
By their numbers in this assay, from the lowest: compound 1; then compound 4; then compound 2. At a limit, above all of these: compound 3.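

This is the only pair shown that differs in one place, and it shows that the half-life responds to a small change at this position. In this assay, 3-methyl-2,5-dioxoimidazolidin-4-yl in place of (3-methyl-2,5-dioxoimidazolidin-4-yl)methyl on the saturated chain carbon gives a 2.5-fold higher number from compound 1 to compound 4 (0.39 log units; beyond the scatter), a modest step. Nothing in the data shown accounts for this step.

Still open, as far as these compounds go, is whether a longer chain carrying the same ring would shorten the half-life further. Also open, from the compounds shown here alone, is how an amine or a carboxylic acid in place of the ring would behave at this position.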